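A few compounds are considered here, and "the series" means these few. Any claim that something is new, unique, unknown or untested is made for them only; others in the source may bear on it.

Compound 1 `O=C1CS/C(=N/Nc2nncc3ccccc23)N1c1ccccc1`: 56 nM
Compound 2 `CCN1C(=O)CS/C1=N/Nc1nncc2ccccc12`: 65 nM

In a functional assay on HeLa cells (Homo sapiens) for antiproliferative activity, read by sulforhodamine B assay, with a stated time of 72 h (on this read-out lower numbers stand for stronger inhibition and higher numbers for weaker inhibition), compound 2 gives 65 nM, level with compound 1 at 56 nM within the scatter. The next structure is compound 3 `O=C1CS/C(=N/Nc2nncc3ccccc23)N1`, not yet measured, and its difference from compound 2 is hydrogen in place of ethyl on an amide-type nitrogen in a ring. Within the data shown here, one measured step bears on this position, a 1.2-fold higher number from compound 1 to compound 2 (0.06 log units; within the scatter), with ethyl in place of phenyl on the same nitrogen. Among the measured compounds shown here, that step is small, but it compares two groups, and no measured compound carries hydrogen there. The expectation is therefore no step beyond the scatter, with a slight lean towards a higher number and a wide margin. The estimated step is a 1.3-fold higher number from compound 2 to compound 3 (0.12 log units; within the scatter). The expected value for compound 3 is 85 nM, with an estimated range of 30 nM to 280 nM.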

Compound 3, half-maximal inhibitory concentration: 57 nM
Estimate against measurement, compound 3: 1.5-fold (0.17 log units) above, and the stated range covers the measured number.
By their numbers in this assay, from the lowest: compounds 1, 3 and 2 (each within the scatter of the next).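

In this assay, hydrogen in place of ethyl gives (a 1.1-fold lower number from compound 2 to compound 3 (0.06 log units; within the scatter)), and hydrogen in place of phenyl gives (a 1.0-fold higher number from compound 1 to compound 3 (0.01 log units; within the scatter)). The amide-type nitrogen now has three measured occupants, phenyl, ethyl and hydrogen, all level within the scatter, so on the shared core neither carbon group shows a measurable gain over the bare nitrogen, a comparison the earlier step between two groups could not make. No data here offer an explanation for this flat result.

On these data alone, whether the same flatness holds for a carboxylic acid or an amine carried on a longer chain at this nitrogen remains open. Only this one position varies among the compounds shown, so the effect of a methoxy group or a chlorine elsewhere on the shared core also remains open.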